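Cytotoxicity Stays Unseen Across a Growing Aryl Group

A few compounds are considered here, and "the series" means these few. Any claim that something is new, unique, unknown or untested is made for them only; others in the source may bear on it.

In an ADME assay on BJ cells (Homo sapiens) for cytotoxicity, with a stated time of 72 h (on this read-out lower numbers stand for an effect already at smaller amounts and higher numbers for an effect only at larger amounts of compound), three compounds were measured, and each reached only the limit of the test:

Compound 1, `CCc1ccc(-c2nc3c(c(C)nn3-c3ccccc3)c(-c3ccccc3C)c2C#N)cc1`: > 20000 nM, a limit.
Compound 2, `CCc1ccc(-c2nc3c(c(C)nn3-c3ccccc3)c(-c3ccccc3S(C)(=O)=O)c2C#N)cc1`: > 20000 nM, a limit.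
Compound 3, `Cc1cccc(-c2nc3c(c(C)nn3-c3ccccc3)c(-c3ccccc3O)c2C#N)c1`: > 20000 nM, a limit.

Compound 3 therefore stands at the same place as the other two, at the limit of > 20000 nM in this assay, at which 3 of the 3 values shown sit, and no number separates them. Among the compounds with values here, the only change between two measured compounds, methylsulfonyl in place of methyl on an aromatic carbon, gives a step that the two limits leave unreadable from compound 1 to compound 2, so its size cannot be read.

Compound 4, `Cc1nn(-c2ccccc2)c2nc(-c3ccc4c(c3)CCCC4)c(C#N)c(-c3ccccc3O)c12`, differs from compound 3 by 1,2,3,4-tetrahydronaphthalen-6-yl in place of 3-methylphenyl on an aromatic carbon. Within the data shown here, no measured step bears on this change; the one step measured was unreadable. The expectation for compound 4 is that it again reaches only the limit in this assay, a step that the limit leaves unreadable from compound 3 to compound 4. Compound 4 is estimated at 30000 nM, between 15000 nM and 80000 nM.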

Compound 4, half-maximal effective concentration: > 20000 nM
Compound 4 gave a limit, no number (the forecaster's own chance of this, stated with the estimate: 90%); the middle value lies beyond the limit too.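

Within the data shown here, compound 3 and compound 4 both reach only a limit, so swapping 3-methylphenyl for 1,2,3,4-tetrahydronaphthalen-6-yl gives no step that can be read. The compounds shown leave open at what concentration, if any, each would harm these cells, since all stop at the same point: the limit of > 20000 nM in this assay, at which 4 of the 4 values shown sit.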